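Swapping an amino side chain for a thioether on a shared core

This account rests on a few compounds, and the source may have more. Where it says the series, first, only, none or still open, it means among the compounds named here.

Measured so far:
compound 1, `CCc1nc(-c2ccc(Cl)cc2Cl)c(CC)nc1NC(COC)COC`, gives 224 nM in an assay on IMR-32 cells for displacement of a labelled ligand from corticotropin-releasing factor receptor 1 (Homo sapiens), read by scintillation counting, with a stated time of 2 h; a higher number here means a weaker inhibitor, a lower number a stronger inhibitor.
compound 2, `CCc1nc(-c2ccc(Cl)cc2Cl)c(CC)nc1NC(C)CN(C)C`, gives 489 nM in this assay.

Compound 2 has the highest of the two numbers, so on this small set it is the weaker binder; its nearest neighbour is compound 1, which lies a 2.2-fold higher number from compound 1 to compound 2 (0.34 log units; beyond the scatter). Both share the same core and differ only in the group carried on the ring nitrogen's neighbouring amino group.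

Compound 3, `CCc1nc(-c2ccc(Cl)cc2Cl)c(CC)nc1SC(C)CC`, has not yet been measured. It differs from compound 2 as follows: (sec-butyl)sulfanyl in place of (1-((dimethylamino)methyl)ethyl)amino on an aromatic carbon. Among the compounds with values here, the one measured step concerns a change on the same position, where a 2.2-fold higher number from compound 1 to compound 2 (0.34 log units; beyond the scatter), and it shows that reshaping this side chain moves the number only modestly. Within the data shown here, no measured pair shows what removing the amino group itself and replacing it with a sulfur-linked chain does, so the step to compound 3 rests on that single, loosely related comparison. The expectation is therefore a change of moderate size at most, with the direction uncertain, leaning toward a somewhat stronger binder; the expected step is a 3.3-fold lower number from compound 2 to compound 3 (0.51 log units; beyond the scatter). Compound 3 is estimated at 150 nM, within a range of 40 nM to 600 nM.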

Compound 3, inhibition constant: 401 nM
Beside the measured number, compound 3's estimate is 2.7-fold (0.43 log units) below it; the range from low to high includes it.
By their numbers in this assay, from the lowest: compounds 1, 3 and 2 (each within the scatter of the next, the first and the last beyond it).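

In this assay, putting (sec-butyl)sulfanyl in place of (1-((dimethylamino)methyl)ethyl)amino gives a 1.2-fold lower number from compound 2 to compound 3 (0.09 log units; within the scatter), and putting it in place of (2-methoxy-1-(methoxymethyl)ethyl)amino gives a 1.8-fold higher number from compound 1 to compound 3 (0.25 log units; within the scatter). Both steps lie within the usual scatter, so compound 3 cannot be told apart from either amino compound, even though those two differ from each other by more than the scatter. The earlier pair kept the amino link throughout, whereas this result shows that at this aromatic carbon, next to the ring nitrogen, a sulfur-linked chain with no hydrogen-bond donor can stand in for an amino-linked one without a readable change in the number, and no supporting data bear on why this is so.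

The compounds shown leave open what the link and the chain each contribute, as compound 3 changes both at once; a sec-butylamino group or a sec-butoxy group at the same carbon would begin to separate the two. Also open, going by these compounds, is how the number responds to a longer chain on the sulfur, or to a carboxylic acid at the end of that chain.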